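Replacing Benzyloxy Where Every Measured Value Is a Limit

The compounds below may be only part of what the source reports. "The series", "measured", "known", "first", "only" and "open" are said of these compounds alone.

Of the compounds shown here, three have so far been tested in a functional assay on HCT-116 cells (Homo sapiens) for inhibition, read by sulforhodamine B assay, with a stated time of 48 h; on this read-out lower numbers stand for stronger inhibition and higher numbers for weaker inhibition. Compound 1 `COc1ccc(C(O)(Cc2ccc(C)cc2)c2cccc3ccccc23)c(OC)c1OC` gives > 20000 nM, which is a limit of the assay and not a number. Compound 2 `COc1ccc(C(O)(Cc2ccc(F)cc2)c2cccc3ccccc23)c(OC)c1OC` gives > 20000 nM, which is also a limit. Compound 3 `COc1ccc(C(OCc2ccccc2)c2cccc3ccccc23)c(OC)c1OC` gives > 20000 nM, so it too stands at a limit and has no number of its own. The whole record so far is the limit of > 20000 nM in this assay, at which 3 of the 3 values shown sit.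

The next compound, compound 4 `COc1ccc(C(c2ccc(O)cc2)c2cccc3ccccc23)c(OC)c1OC`, differs from compound 3 as follows: 4-hydroxyphenyl in place of benzyloxy on a saturated chain carbon bound to two aromatic carbons. In words, 4-hydroxyphenyl stands in place of benzyloxy on a saturated chain carbon bound to two aromatic carbons.

For the measured compounds named here, only one measured step exists, a step that the two limits leave unreadable from compound 1 to compound 2. It is a different change, fluoro in place of methyl on an aromatic carbon, and its size cannot be read, so it offers no size to carry over. The expectation therefore starts from compound 3 alone and is weakly grounded. A modest move toward stronger inhibition is expected in this assay, although a further reading at the limit would be no surprise. The estimated change is an at least 1.3-fold lower number from compound 3 to compound 4 (0.12 log units; that floor lies within the scatter). For compound 4 the expected value is 15000 nM, with an estimated range of 4000 nM to 30000 nM.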

Compound 4, half-maximal inhibitory concentration: 16000 nM
Estimate against measurement, compound 4: 1.1-fold (0.03 log units) below, and the stated range covers the measured number.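

In this assay compound 3 stands at > 20000 nM, which is a limit and not a number. For the compounds shown here, with 4-hydroxyphenyl in place of benzyloxy on a saturated chain carbon bound to two aromatic carbons, the assay returns a number for the first time, and the change reads as an at least 1.2-fold lower number from compound 3 to compound 4 (0.09 log units; that floor lies within the scatter), so only a floor on its size is known and that floor does not set compound 4 apart from compound 3. Compound 4 therefore shows that this position can carry a group that gives a number in the assay, though it remains the single such compound in a record otherwise made up of limits: the limit of > 20000 nM in this assay, at which 3 of the 4 values shown sit.

The compounds shown leave open whether the step belongs to the hydroxy group or to the aromatic ring placed directly on this carbon, and whether plain phenyl, an amine or a carboxylic acid in the same place would give a lower number. Going by these compounds, the step from compound 1 to compound 2 cannot be read, so how methyl and fluoro compare on that aromatic carbon also stays open.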